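The source may hold more compounds than are shown below. What is called first, only, known or untested is meant among the compounds shown, and "the series" means these compounds.

Compound 1 `CCN1C(=O)N(CC)C2C1NC(=S)N2/N=C/C=C/c1ccccc1[N+](=O)[O-]` and compound 2 `CCN1C(=O)N(CC)C2C1NC(=S)N2/N=C/C=C/c1ccccc1OC` share one core and differ in a single spot: methoxy in place of nitro on an aromatic carbon. In an ADME assay on HEK293 cells (Homo sapiens) for inhibition, read by MTT assay, with a stated time of 72 h (on this read-out lower numbers stand for stronger inhibition and higher numbers for weaker inhibition), compound 1 gives 19300 nM, while in this assay compound 2 gives 86100 nM, so the change brought a 4.5-fold higher number from compound 1 to compound 2 (0.65 log units; beyond the scatter). In this assay compound 3 `CCN1C(=O)N(CC)C2C1N=C(SC)N2/N=C/C=C/c1ccccc1[N+](=O)[O-]` gives "not determined" (no result reported), so there is no number for it in this assay. How the core of compound 3 differs from the core of compound 1 is not broken down here. Compound 4 `CCN1C(=O)N(CC)C2C1N=C(SC)N2/N=C/C=C/c1ccccc1OC` stands to compound 3 as compound 2 stands to compound 1: methoxy in place of nitro on an aromatic carbon. The surroundings of the place are described in the same words for both pairs, so this is the same change. With no value for compound 3, the expectation for compound 4 rests only on compound 2 giving 86100 nM and on the step being a 4.5-fold higher number from compound 1 to compound 2 (0.65 log units; beyond the scatter). Compound 4 is therefore expected near 80000 nM, likely between 20000 nM and 300000 nM.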

Compound 4, half-maximal inhibitory concentration: 145000 nM
Estimate against measurement, compound 4: 1.8-fold (0.26 log units) below, and the stated range covers the measured number.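

For the compounds shown here, with no number for compound 3 in this assay, no step from compound 3 to compound 4 can be read. Whether swapping nitro for methoxy shifts the number as much on the core of compound 3 as on the core of compound 1 stays open, and no measurement here offers an explanation for any of these values.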